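The source may report more compounds than this note shows. Statements on the series, on what has been measured and on what is new or still open speak of the compounds shown alone.

Compound 2 `Cc1cc(C(=O)O)c(C)n1-c1cccc(C2CC2)c1F` gives 200 nM in an assay on cells for inhibition of Palmitoleoyl-protein carboxylesterase NOTUM variant C330S (Homo sapiens), read by fluorescence, with a stated time of 40 min (a lower number here means a stronger inhibitor, a higher number a weaker inhibitor), the lowest of the two numbers recorded, while compound 1 `Cc1cc(C(=O)O)c(C)n1-c1cccc(C(C)C)c1` gives 360 nM in this assay, a gap within the scatter. Compound 3 `Cc1cc(C(=O)O)c(C)n1-c1cccc(C(C)C)c1F` is yet to be measured. It differs from compound 2 in one place: isopropyl in place of cyclopropyl on an aromatic carbon. No change between measured compounds that differ in one place is available, so the expected step from compound 2 to compound 3 is a 1.4-fold higher number from compound 2 to compound 3 (0.15 log units; within the scatter), none beyond the scatter. Compound 3 is therefore expected to give about 280 nM in this assay, estimated between 120 nM and 650 nM.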

Compound 3, half-maximal inhibitory concentration: 150 nM
Compound 3: the middle estimate sits 1.9-fold (0.27 log units) above what was measured; the range from low to high includes it.
By their numbers in this assay, from the lowest: compounds 3, 2 and 1 (each within the scatter of the next, the first and the last beyond it).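

In this assay, isopropyl in place of cyclopropyl on this aromatic carbon gives a 1.3-fold lower number from compound 2 to compound 3 (0.12 log units; within the scatter), so with the fluoro group present these two groups are not told apart. Among the compounds shown here, with isopropyl held, fluoro in place of hydrogen gives a 2.4-fold lower number from compound 1 to compound 3 (0.38 log units; beyond the scatter), the one step here beyond the scatter, though modest. Nothing available explains either step. The compounds shown leave open whether a methoxy group or a longer chain on this aromatic carbon would keep these numbers, and what a chloro group in place of the fluoro group would give.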